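This account rests on a few compounds, and the source may have more. Where it says the series, first, only, none or still open, it means among the compounds named here.

Measured so far:
compound 1, `COC(=O)N1N=C(c2ccccc2)NN=C1c1ccccc1` — in a functional assay on P388 cells (Mus musculus) for antiproliferative activity, read by MTT assay (a higher number here means a weaker inhibitor, a lower number a stronger inhibitor), compound 1 gives > 100000 nM, which is a limit of the assay and not a number.
compound 2, `CC(C)CCOC(=O)N1N=C(c2ccccc2)NN=C1c1ccccc1` — in this assay compound 2 gives 24600 nM.

Compound 2 thus holds the only number shown in this assay; the other value is a limit. Going by the values given here, the single measured step, an at least 4.0-fold lower number from compound 1 to compound 2 (0.60 log units; beyond the scatter), lowered the number. Compound 3, `O=C(OCCCl)N1N=C(c2ccccc2)NN=C1c1ccccc1`, differs from compound 2 by chloro in place of isopropyl on a saturated chain carbon, two bonds along the chain from an oxygen next to a carbonyl group. Among the compounds with values here, no measured step involves a chloro group; the step from compound 1 to compound 2 concerns growth of the chain on the same carbamate oxygen, and compound 3 carries a shorter chain than compound 2. Compound 3 is therefore expected to give a somewhat higher number than compound 2, with a real chance of sitting at the limit (the limit of > 100000 nM in this assay, at which 1 of the 2 values shown sits). The estimate for compound 3 in this assay is 50000 nM, ranging from 15000 nM to 150000 nM. The expected step is a 2.0-fold higher number from compound 2 to compound 3 (0.31 log units; beyond the scatter).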

Compound 3, half-maximal inhibitory concentration: > 100000 nM
Compound 3 gave a limit, no number; the forecaster's own chance of this, stated with the estimate: 30%; middle value at least 2.0-fold (0.30 log units) away from the limit.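

Chloro in place of isopropyl, on a saturated chain carbon two bonds along the chain from an oxygen next to a carbonyl group, gives an at least 4.0-fold higher number from compound 2 to compound 3 (0.60 log units; beyond the scatter) in this assay. This shows that the change at this position can also raise the number, so the lower number of compound 2 does not carry over to the 2-chloroethyl chain. The steps between compound 1 and compound 3 cannot be read, and compound 2 remains the only compound of the three with a number: the limit of > 100000 nM in this assay, at which 2 of the 3 values shown sit.

Compound 3 changes both the end group and the chain length at once, so the compounds shown do not tell these two apart. From the compounds shown here alone, a 5-chloropentyl chain or an unbranched pentyl chain on the same oxygen remains open.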